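Replacing the ring sulfonyl on the piperidine nitrogen with an open chain

The source may report more compounds than this note shows. Statements on the series, on what has been measured and on what is new or still open speak of the compounds shown alone.

Three compounds share one core and differ only in the group carried on the amine nitrogen of the six-membered ring. Compound 1 `O=C(c1ccccc1)N1CCC(NS(=O)(=O)c2cc(S(=O)(=O)c3ccccc3)ccc2C(F)(F)F)CC1` bears a benzoyl group there; in an assay on U2OS cells for inhibition of secreted frizzled-related protein 1 (Homo sapiens), read by a luciferase reporter, with a stated time of 18 h (on this read-out lower numbers stand for an effect already at smaller amounts and higher numbers for an effect only at larger amounts of compound), compound 1 gives 250 nM. Compound 2 `CN(C)c1ccc(C(=O)N2CCC(NS(=O)(=O)c3cc(S(=O)(=O)c4ccccc4)ccc3C(F)(F)F)CC2)cc1` adds a dimethylamino group to that benzoyl, and in this assay compound 2 gives 190 nM. Compound 3 `N#Cc1cccc(S(=O)(=O)N2CCC(NS(=O)(=O)c3cc(S(=O)(=O)c4ccccc4)ccc3C(F)(F)F)CC2)c1` carries a (3-cyanophenyl)sulfonyl group instead, and in this assay compound 3 gives 170 nM. Compound 3 has the lowest of the three numbers, but its distance to both neighbours is small: a 1.5-fold lower number from compound 1 to compound 3 (0.17 log units; within the scatter) and a 1.1-fold lower number from compound 2 to compound 3 (0.05 log units; within the scatter), so the three compounds cannot be ordered.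

Compound 4 `CC(C)(O)CCN1CCC(NS(=O)(=O)c2cc(S(=O)(=O)c3ccccc3)ccc2C(F)(F)F)CC1` is the next member. The change is 3-hydroxy-3-methylbutyl in place of (3-cyanophenyl)sulfonyl on an amine nitrogen in a ring. Within the data shown here, the steps that bear on it are those at the same position, from compound 1 and compound 2 to compound 3, both within the scatter, which suggests that this nitrogen tolerates different groups. Yet here an aromatic sulfonyl gives way to a short chain with a hydroxyl, a larger departure than any measured step. The author therefore expects a modest rise in the number, a 2.1-fold higher number from compound 3 to compound 4 (0.31 log units; beyond the scatter), and estimates for compound 4 in this assay a value of 350 nM, between 120 nM and 1200 nM.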

Compound 4, half-maximal effective concentration: 630 nM
Estimate against measurement, compound 4: 1.8-fold (0.26 log units) below; measured number inside the range.
By their numbers in this assay, from the lowest: compounds 3, 2 and 1 (each within the scatter of the next); then compound 4.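

Compound 4 shows that the tolerance at this amine nitrogen has a limit. In this assay, the three earlier groups stayed within the scatter of one another, whereas the 3-hydroxy-3-methylbutyl chain gives a 3.7-fold higher number from compound 3 to compound 4 (0.57 log units; beyond the scatter), a 3.3-fold higher number from compound 2 to compound 4 (0.52 log units; beyond the scatter) and a 2.5-fold higher number from compound 1 to compound 4 (0.40 log units; beyond the scatter), all three beyond the scatter but modest in size. The change takes away an aromatic ring and the sulfonyl or carbonyl that linked it to the nitrogen, and it brings in a chain with a hydroxyl, but no measurement here explains why the number rises.

The compounds shown leave open which part of this exchange goes with the higher number, as the ring, the linking group and the hydroxyl all change in a single step. A 3-methylbutyl chain without the hydroxyl, a benzyl group, or a chain ending in a carboxylic acid on the same nitrogen would begin to separate these parts, and a longer chain would show whether the length of the chain counts at this position.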